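The source may hold more compounds than are shown below. What is called first, only, known or untested is meant among the compounds shown, and "the series" means these compounds.

- compound 1 `CC(Oc1ccc(Cl)cc1Cl)C(=O)NCc1cccc(Cl)c1`: 19000 nM
- compound 2 `Cc1cccc(CNC(=O)C(C)Oc2ccc(Cl)cc2Cl)c1`: 45000 nM

In an ADME assay on CHO cells (Cricetulus griseus) for cytotoxicity, read by LDH release (a higher number here means a weaker inhibitor, a lower number a stronger inhibitor), compound 2 gives 45000 nM, the higher of the two numbers. Compound 3 `Cc1ccccc1CNC(=O)C(C)Oc1ccc(Cl)cc1Cl` has 2-methylphenyl in place of 3-methylphenyl on a saturated chain carbon bound to an amide-type nitrogen. Going by the values given here, the only measured step is a 2.4-fold higher number from compound 1 to compound 2 (0.37 log units; beyond the scatter), with methyl in place of chloro on an aromatic carbon. That is a different change, so it is only a loose guide to size and gives no direction. The expected change is a 1.2-fold lower number from compound 2 to compound 3 (0.07 log units; within the scatter), with none beyond the scatter anticipated. For compound 3 the estimate is 38000 nM, with an expected range of 16000 nM to 85000 nM.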

Compound 3, half-maximal inhibitory concentration: > 100000 nM
Compound 3: no number, only a limit; the forecaster's own chance of this, stated with the estimate: 15%; middle value at least 2.6-fold (0.42 log units) from the limit.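

Joining the same atoms differently matters here: in this assay, 2-methylphenyl in place of 3-methylphenyl gives an at least 2.2-fold higher number from compound 2 to compound 3 (0.34 log units; beyond the scatter), a shift beyond the scatter with no atom gained or lost. In place of 3-chlorophenyl, the same group gives an at least 5.2-fold higher number from compound 1 to compound 3 (0.72 log units; beyond the scatter). The value of compound 3 is a limit of the assay and not a number: the limit of > 100000 nM in this assay, at which 1 of the 3 values shown sits.

As far as these compounds go, how far the true number of compound 3 lies past that limit stays open. So does how an amine or a carboxylic acid in place of the methyl would read.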